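Chloro in place of hydrogen: a step without an anchor

This account rests on a few compounds, and the source may have more. Where it says the series, first, only, none or still open, it means among the compounds named here.

For the measured compounds named here, in a functional assay on B16-F10 cells (Mus musculus) for inhibition, read by MTT assay, with a stated time of 72 h (a higher number here means a weaker inhibitor, a lower number a stronger inhibitor), the only number so far belongs to compound 1 (`CC1(C)CC(NC(=S)Nc2cccc(C#N)c2)c2cc(Br)ccc2O1`), which gives 7000 nM. Compound 2 (`CC1(C)CC(NC(=O)Nc2ccccc2)c2cc(Cl)ccc2O1`) has no number to start from, and the entry for compound 2 reads "not determined" (no result reported). Compound 3 (`CC1(C)CC(NC(=O)Nc2ccc(Cl)cc2)c2cc(Cl)ccc2O1`) differs from compound 2 by chloro in place of hydrogen on an aromatic carbon, with the chloro in place of hydrogen on an aromatic carbon, para to a large group, turning phenyl into 4-chlorophenyl. Going by the values given here, no measured pair shows what such a change does in this assay, and the missing starting value leaves the step itself unreadable. No step beyond the usual scatter is expected, and neither direction is favoured. Among the compounds with values here, the only number to lean on is the one from compound 1 at 7000 nM, so the range stays wide. For compound 3 the expected value is 8000 nM, with an estimated range of 2500 nM to 25000 nM.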

Compound 3, half-maximal inhibitory concentration: 32000 nM
Beside the measured number, compound 3's estimate is 4.0-fold (0.60 log units) below it; the whole stated range lies below it.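

In this assay compound 3 gives 32000 nM but compound 2 has no number to pair with it, so no step can be read between them. As far as these compounds go, what chloro in place of hydrogen does stays open. No evidence on the result is at hand.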